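The source may hold more compounds than are shown below. What is called first, only, known or untested is meant among the compounds shown, and "the series" means these compounds.

Measured compounds:
Compound 1 `CC1CCN(Cc2ccc3nc(NC(=O)N/N=C/c4cn(Cc5cccc(Cl)c5)c5ccccc45)sc3c2)CC1` gives 280 nM in a functional assay on NCI-H460 cells (Homo sapiens) for cytotoxicity, read by MTT assay, with a stated time of 72 h; a higher number here means a weaker inhibitor, a lower number a stronger inhibitor.
Compound 2 `CC1CCN(Cc2ccc3nc(NC(=O)N/N=C4\C(=O)Nc5ccc(F)cc54)sc3c2)CC1` gives 1430 nM in this assay.
Compound 3 `CCN(CC)Cc1ccc2nc(NC(=O)N/N=C/c3cn(Cc4cccc(Cl)c4)c4ccccc34)sc2c1` gives 220 nM in this assay.

Compound 1 and compound 3 share a core and differ in one place: diethylamino in place of 4-methylpiperidin-1-yl on a saturated chain carbon bound to an aromatic carbon. That change made a step of a 1.3-fold lower number from compound 1 to compound 3 (0.10 log units; within the scatter), so the two numbers cannot be told apart. Compound 2 has a different core from compound 1; how the two cores differ is not broken down here. Compound 2 stands with the highest number of the three, beyond the scatter from both compound 1 and compound 3.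

Compound 4 `CCN(CC)Cc1ccc2nc(NC(=O)N/N=C3\C(=O)Nc4ccc(F)cc43)sc2c1` has not been measured. It carries the core of compound 2 with the same kind of change already seen once: diethylamino in place of 4-methylpiperidin-1-yl on a saturated chain carbon bound to an aromatic carbon. Since the same change, in the same place, gave a 1.3-fold lower number from compound 1 to compound 3 (0.10 log units; within the scatter), the step from compound 2 to compound 4 is expected to be small as well, estimated at a 1.2-fold lower number from compound 2 to compound 4 (0.08 log units; within the scatter). On that basis compound 4 is estimated at 1200 nM in this assay, with a likely range from 500 nM to 3000 nM.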

Compound 4, half-maximal inhibitory concentration: 1060 nM
Compound 4: middle estimate off by 1.1-fold (0.05 log units), on the high side; measured number inside the range.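

In this assay, replacing 4-methylpiperidin-1-yl with diethylamino a second time gave a 1.3-fold lower number from compound 2 to compound 4 (0.13 log units; within the scatter), so these two numbers cannot be told apart. Set beside the first case, the change looks the same on both cores, with neither step rising above the scatter: the same change on two cores in this assay, a 1.3-fold lower number (0.10 log units; within the scatter) from compound 1 to compound 3 and a 1.3-fold lower number (0.13 log units; within the scatter) from compound 2 to compound 4, 1.1-fold (0.03 log units) apart, within the scatter of two such steps. This shows that, on these two cores, the swap leaves no measurable mark on the number, but it does not show that a change with a clear effect would carry from one core to another, since a step too small to read says little about how well steps transfer.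

The compounds shown leave open what a morpholine ring, a carboxylic acid or a longer chain would do on the same saturated chain carbon bound to an aromatic carbon, where a larger step might appear. Within the data shown here, with only two cores here, it also remains open whether this swap would stay as small on a third core.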